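Swapping the charged ring group at the end of the chain

A few compounds are considered here, and "the series" means these few. Any claim that something is new, unique, unknown or untested is made for them only; others in the source may bear on it.

Compound 1 `Cc1ccc(-n2cc(C(=O)Nc3cc(F)cc(F)c3)c(=O)c3ccc(N(C)C)nc32)cc1OCCCCCCC[N+]12CCN(CC1)CC2` is one of a set of related compounds examined in an assay on LX2 cells for inhibition of COL1A1 promoter (Homo sapiens), read by a luciferase reporter, with a stated time of 24 h, tested at 50 uM; on this read-out lower numbers stand for a weaker effect and higher numbers for a stronger effect at the one concentration tested. In this assay compound 1 gives 9.71%, the lowest of the two numbers reported; its nearest neighbour, compound 2 `CN(C)c1ccc2c(=O)c(C(=O)Nc3cc(F)cc(F)c3)cn(-c3ccc(Cl)c(OCCCCCCC[N+]45CCN(CC4)CC5)c3)c2n1`, gives 18.7%, and the step of a number 9 percentage points higher from compound 1 to compound 2 (within the scatter) comes from a chloro in place of a methyl on an aromatic carbon. Among the compounds with values here, a third member, compound 3 `CN(C)c1ccc2c(=O)c(C(=O)Nc3cc(F)cc(F)c3)cn(-c3ccc(OCCCCCCC[N+]4(C)CCCC4)cc3F)c2n1`, is reported in this assay only as "not active" (no number reported), with no number, and it differs from the others in more than one place, so no single step can be drawn from it.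

Compound 4 `Cc1ccc(-n2cc(C(=O)Nc3cc(F)cc(F)c3)c(=O)c3ccc(N(C)C)nc32)cc1OCCCCCCC[N+]1(C)CCCCC1` is not yet measured. It differs from compound 1 as follows: a group of 7 heavy atoms (6 carbon, 1 nitrogen; one six-membered non-aromatic ring with 1 hetero atom) in place of a group of 8 heavy atoms (6 carbon, 2 nitrogen; 2 six-membered non-aromatic rings with 2 hetero atoms each), on a saturated chain carbon, seven bonds along the chain from an oxygen on an aromatic ring. Within the data shown here, no measured step changes this part of the molecule, so there is nothing to show whether such a change moves the read-out at all. Among the measured compounds shown here, the one step that is known, from compound 1 to compound 2, lies within the scatter, and the starting number for compound 1 is itself small.

On that basis compound 4 is expected to give about 11%, with a range from 0% to 25%. The expected step of a number 1.3 percentage points higher from compound 1 to compound 4 (within the scatter) is therefore no change beyond the scatter.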

Compound 4, a percentage reported as inhibition, at one concentration (the size of the read-out at that concentration, not a potency): 45.1%
The estimate for compound 4 lay 34.1 percentage points below the measured number; the measured number lies above the stated range.
By their numbers in this assay, from the lowest: compounds 1 and 2 (each within the scatter of the next); then compound 4.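

In this assay the group at the end of the chain turns out to matter: replacing the two-ring charged group with the one-ring group, on a saturated chain carbon, seven bonds along the chain from an oxygen on an aromatic ring, gives a number 35.4 percentage points higher from compound 1 to compound 4 (beyond the scatter) and is the first change shown here to move the read-out beyond the usual scatter. Within the data shown here, the only step readable before it, a number 9 percentage points higher from compound 1 to compound 2 (within the scatter) for a chloro in place of a methyl on an aromatic carbon, did not do so, and the new step occurs although both end groups carry a net charge of +1, so that net charge alone does not set the read-out in this pair. No measurement shown explains why this exchange raises the number.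

It remains open whether the same exchange would also raise the number for the chloro compound, compound 2, since the matching pair is not among the compounds shown. On these data alone, it is also open how a morpholine ring at the chain end or a longer chain would read, and a single-concentration percentage cannot say whether potency changes.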